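The compounds below may be only part of what the source reports. "The series", "measured", "known", "first", "only" and "open" are said of these compounds alone.

Of the compounds shown here, three of a shared core have been measured in a functional assay on A549 cells (Homo sapiens) for antiproliferative activity, read by MTT assay, with a stated time of 72 h; a higher number here means a weaker inhibitor, a lower number a stronger inhibitor. Compound 1 `COc1ccc(N2C(=O)COc3ccc(-c4cnc(OC)c(NS(=O)(=O)c5ccc(F)cc5)c4)cc32)cc1` carries a 4-methoxyphenyl on the ring amide nitrogen and gives 1350 nM. Compound 2 `O=C1COc2ccc(-c3ccc(O)cc3)cc2N1` keeps a hydrogen on that nitrogen; in this assay compound 2 reaches only the assay limit > 40000 nM, so a limit rather than a number is known for it. Compound 3 `O=C1COc2ccc(-c3cnc4ccccc4c3)cc2N1` likewise gives only the limit > 40000 nM in this assay. Compound 2 therefore stands at the limit of > 40000 nM in this assay, at which 2 of the 3 values shown sit, together with compound 3, while compound 1 alone returns a number. Compound 4 `COc1ccc(N2C(=O)COc3ccc(-c4ccc(O)cc4)cc32)cc1` has not been measured; it differs from compound 2 by 4-methoxyphenyl in place of hydrogen on an amide-type nitrogen in a ring. Among the measured compounds shown here, compound 1 carries this same 4-methoxyphenyl, yet it also differs from compound 2 elsewhere, so no step between measured compounds isolates this change. A gain in potency is expected from the change, estimated as an at least 2.6-fold lower number from compound 2 to compound 4 (0.42 log units; beyond the scatter), though a limit may again be returned. Compound 4 is estimated at 15000 nM, between 3000 nM and 40000 nM.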

Compound 4, half-maximal inhibitory concentration: > 40000 nM
Compound 4 ended at the assay's limit; the forecaster's own chance of this, stated with the estimate: 35%; middle value at least 2.6-fold (0.42 log units) away from the limit.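

Compound 2 and compound 4 each return only a limit in this assay, so the step between them cannot be read. The compounds shown leave open whether 4-methoxyphenyl in place of hydrogen on the amide-type nitrogen changes potency at all, because both compounds rest at one value: the limit of > 40000 nM in this assay, at which 3 of the 4 values shown sit.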